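The source may hold more compounds than are shown below. What is called first, only, known or untested is meant among the compounds shown, and "the series" means these compounds.

Of the compounds shown here, three of a shared core have been measured in a functional assay on DU-145 cells (Homo sapiens) for inhibition, read by trypan blue exclusion, with a stated time of 72 h; on this read-out higher numbers stand for weaker inhibition and lower numbers for stronger inhibition. Compound 1 `Cn1c(=O)c(S(=O)(=O)c2ccc(F)cc2F)cc2cnc(Nc3cccc4[nH]ccc34)nc21` gives 750 nM. Compound 2 `Cn1c(=O)c(S(=O)(=O)c2ccc(F)cc2[N+](=O)[O-])cc2cnc(Nc3ccc4[nH]ccc4c3)nc21` gives 1500 nM. Compound 3 `Cn1c(=O)c(S(=O)(=O)c2ccc(F)cc2F)cc2cnc(Nc3ccc4occc4c3)nc21` gives 15000 nM. Among these numbers, compound 2 stands within the usual scatter of compound 1, while compound 3 lies well beyond it with the highest number of the three. Going by the values given here, the only single-site step among the measured compounds is a 20-fold higher number from compound 1 to compound 3 (1.30 log units; beyond the scatter), a change on the aromatic nitrogen substituent, not at the sulfonyl sulfur.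

Compound 4 `Cn1c(=O)c(S(=O)(=O)Cc2ccc(F)cc2F)cc2cnc(Nc3ccc4[nH]ccc4c3)nc21` is the next compound, and it differs from compound 2 by 2,4-difluorobenzyl in place of 4-fluoro-2-nitrophenyl on a sulfonyl sulfur. Among the compounds with values here, no measured step touches the sulfonyl sulfur, so nothing in the data speaks directly to this change; the step from compound 1 to compound 3 concerns another site and is not a guide here. The expectation is therefore a step of no change at the digits printed from compound 2 to compound 4 (within the scatter), that is, no change beyond the scatter in this assay. Compound 4 is accordingly estimated at 1500 nM, with a range from 500 nM to 5000 nM.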

Compound 4, half-maximal inhibitory concentration: 1000 nM
Compound 4: middle estimate off by 1.5-fold (0.18 log units), on the high side, and the stated range covers the measured number.
By their numbers in this assay, from the lowest: compounds 1, 4 and 2 (each within the scatter of the next); then compound 3.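

Going by these compounds alone, at the sulfonyl sulfur, the step of a 1.5-fold lower number from compound 2 to compound 4 (0.18 log units; within the scatter) in this assay lies within the scatter, the first direct reading at this site. A methylene-linked 2,4-difluorobenzyl, with no nitro group and no hydrogen-bond acceptors, thus reads the same on this assay as 4-fluoro-2-nitrophenyl, so this exchange leaves no difference that can be told apart from the scatter, unlike the large step at the aromatic nitrogen substituent, a 20-fold higher number from compound 1 to compound 3 (1.30 log units; beyond the scatter). No supporting measurement bears on why these two groups read alike.

The compounds shown leave open whether the sulfonyl sulfur would read the same with a group lacking an aromatic ring, such as a short alkyl chain, or with one carrying an amine or a carboxylic acid. Going by these compounds, it is also open whether this exchange would read the same with the 1H-indol-4-yl group of compound 1 on the nitrogen.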